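A Naphthalen-2-yl End Group Replaces 4-Chlorophenyl

The source may report more compounds than this note shows. Statements on the series, on what has been measured and on what is new or still open speak of the compounds shown alone.

Compound 1 `CC(C)c1nc2cc(-c3nc4cc(-c5nc6cc(-c7ccccc7)ccc6[nH]5)ccc4[nH]3)ccc2[nH]1`: in a functional assay on RPMI 8402 cells (Homo sapiens) for cytotoxicity (a higher number here means a weaker inhibitor, a lower number a stronger inhibitor), compound 1 gives 60 nM
Compound 2 `Clc1ccc(-c2ccc3[nH]c(-c4ccc5[nH]c(-c6ccc7[nH]cnc7c6)nc5c4)nc3c2)cc1`: in this assay compound 2 gives 90 nM

Only these two compounds have been measured, and the gap between them lies within the usual scatter of repeated measurements, so neither can be called stronger or weaker than the other; compound 2 stands, in effect, level with compound 1. Going by the values given here, no pair of measured compounds differs in just one place, so there is no single-change step to draw on.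

Compound 3 `c1ccc2cc(-c3ccc4[nH]c(-c5ccc6[nH]c(-c7ccc8[nH]cnc8c7)nc6c5)nc4c3)ccc2c1` has not yet been measured in this assay. It differs from compound 2 in one place: naphthalen-2-yl in place of 4-chlorophenyl on an aromatic carbon. Both the leaving group and the entering group are uncharged aromatic carbon rings with no hydrogen-bond donors or acceptors, and nothing in the data shows how such an exchange moves the number. The step from compound 2 to compound 3 is therefore expected to be small, a 1.1-fold lower number from compound 2 to compound 3 (0.05 log units; within the scatter), with no clear direction beyond the scatter. For compound 3 the estimate is 80 nM, with a range from 35 nM to 200 nM.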

Compound 3, half-maximal inhibitory concentration: 80 nM
For compound 3 middle estimate and measured number coincide at the digits printed; the range from low to high includes it.
By their numbers in this assay, from the lowest: compounds 1, 3 and 2 (each within the scatter of the next).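

Going by these compounds alone, replacing 4-chlorophenyl with naphthalen-2-yl on an aromatic carbon gives the first single-change step, and in this assay it reads a 1.1-fold lower number from compound 2 to compound 3 (0.05 log units; within the scatter) for the exchange. This position therefore accepts an end group of 2 six-membered aromatic rings of carbon only and 10 heavy atoms, in place of one such ring and 7 heavy atoms, and the loss of the chlorine, without a shift that can be told from the scatter. No measurement shown here explains why the number holds level.

Both groups carry no net charge and have no hydrogen-bond donors or acceptors, so this step says nothing about how an amine or a carboxylic acid would behave at this position. From the compounds shown here alone, whether a pyridine ring or a longer alkyl chain there would move the number beyond the scatter also remains open.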